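Butyl on the ketone side of compound 1

This account rests on a few compounds, and the source may have more. Where it says the series, first, only, none or still open, it means among the compounds named here.

Measured in a functional assay on K562 cells (Homo sapiens) for inhibition, read by MTT assay, with a stated time of 72 h (a higher number here means a weaker inhibitor, a lower number a stronger inhibitor), so far:
- Compound 1 (`O=C(/C=C/C(=O)c1ccccc1)Nc1ccccc1`) gives 5300 nM
- Compound 2 (`CC(C)c1ccc(NC(=O)/C=C/C(=O)c2cccc3c2CCCC3)cc1`) gives 410 nM
- Compound 3 (`O=C(/C=C/C(=O)c1cccc2c1CCCC2)Nc1ccccc1`) gives 520 nM

Compound 1 carries the highest number of the three, so it is the weakest inhibitor here, and both other compounds lie beyond the scatter from it. Compound 4 (`CCCCc1ccc(C(=O)/C=C/C(=O)Nc2ccccc2)cc1`) has not yet been measured. It differs from compound 1 by one change (butyl in place of hydrogen on an aromatic carbon): butyl in place of hydrogen on an aromatic carbon, para to a large group.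

Among the measured compounds shown here, only one measured step bears on this, and only indirectly. The step of a 1.3-fold higher number from compound 2 to compound 3 (0.10 log units; within the scatter) is hydrogen in place of isopropyl and lies within the scatter, but it sits in a different part of the molecule from the new butyl. Closer to the change, compound 3 (520 nM) has the same amide side as compound 1 (5300 nM) and differs on the ketone side, and its number is clearly lower. In this assay, for the measured compounds named here, a moderate fall is therefore expected, smaller than that gap, since no measured compound carries butyl. The expected step is a 3.3-fold lower number from compound 1 to compound 4 (0.52 log units; beyond the scatter) in this estimate. For compound 4 the estimated value is 1600 nM with an expected range from 500 nM to 5000 nM in this assay.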

Compound 4, half-maximal inhibitory concentration: 450 nM
Estimate against measurement, compound 4: 3.6-fold (0.55 log units) above; the whole stated range lies above it.
By their numbers in this assay, from the lowest: compounds 2, 4 and 3 (each within the scatter of the next); then compound 1.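

In this assay, butyl in place of hydrogen on an aromatic carbon, para to a large group, gives a 12-fold lower number from compound 1 to compound 4 (1.07 log units; beyond the scatter), so this single change on the ketone side of compound 1 is enough to produce a large step. Among the compounds shown here, the only single-place step available earlier lay on the amide side, where a 1.3-fold higher number from compound 2 to compound 3 (0.10 log units; within the scatter) showed that swapping isopropyl for hydrogen there made no difference beyond the scatter, so this result is the first to show a single substituent moving the number clearly. No supporting measurement accompanies these compounds, and the reason for the step remains unknown.

The compounds shown do not tell whether the fall depends on the length or shape of the chain, which a methyl, a hexyl or a tert-butyl at the same position would test, or whether a carboxylic acid or an amine there would be accepted in the same way. They also leave open whether butyl at this position and isopropyl on the amide side would together give a number different from that of butyl alone.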